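Chloro for (methylsulfonyl)methyl on a fused imidazopyridine-type core

The source may hold more compounds than are shown below. What is called first, only, known or untested is meant among the compounds shown, and "the series" means these compounds.

Measured compounds:
compound 1 `Cc1cn2cccc(OCc3ccccc3)c2n1`, 70%
compound 2 `Cc1nc2c(OCc3ccccc3)cccn2c1CS(C)(=O)=O`, 0%

In a functional assay on the whole organism (stomach) for inhibition, with Canis familiaris (Canis lupus familiaris) as the target, at a dose of 5 mg/kg by the intravenous route (a higher number here means a stronger effect of the compound at the dose given, a lower number a weaker effect), compound 2 gives 0%, the lowest of the two numbers, with compound 1 standing above it. Among the measured compounds shown here, the single known step, a number 70 percentage points lower from compound 1 to compound 2 (beyond the scatter), is large. Compound 3 `Cc1nc2c(OCc3ccccc3)cccn2c1Cl` is not yet measured. It differs from compound 2 by chloro in place of (methylsulfonyl)methyl on an aromatic carbon. Since the large group that entered in that step leaves here and a small one enters, a rise in this assay is expected, though its size is uncertain. Compound 3 is therefore estimated at 45%, between 10% and 80%, a step of a number 45 percentage points higher from compound 2 to compound 3 (beyond the scatter).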

Compound 3, a percentage reported as inhibition, in the whole organism at one dose (the size of the read-out at that dose, not a potency): 37%
Compound 3: middle estimate off by 8 percentage points, on the high side; the measured number falls inside the stated range.
By their numbers in this assay, from the lowest: compound 2; then compound 3; then compound 1.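

Replacing (methylsulfonyl)methyl with chloro on this aromatic carbon gives a number 37 percentage points higher from compound 2 to compound 3 (beyond the scatter) in this assay, so a substituent here does not in itself abolish the effect. Yet chloro in place of hydrogen still gives a number 33 percentage points lower from compound 1 to compound 3 (beyond the scatter), leaving compound 1, with hydrogen at this carbon, highest of the three. Nothing available explains these differences. On these data alone, it remains open whether a fluoro, a methyl or an amine at this carbon would bring the number closer to that of compound 1.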